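Splenocyte activation series: benzylsulfanyl to methylamino

A few compounds are considered here, and "the series" means these few. Any claim that something is new, unique, unknown or untested is made for them only; others in the source may bear on it.

Compound 1 `Nc1nc(SCc2ccccc2)nc2c1nc(O)n2Cc1ccccc1`: 0.1 uM
Compound 2 `CSc1nc2c(N)ncnc2n1Cc1ccccc1`: > 10 uM

Within the data shown here, compound 1 is the only member with a number in a functional assay (spleen, spleen) for activation, with Mus musculus as the target; on this read-out lower numbers stand for an effect already at smaller amounts and higher numbers for an effect only at larger amounts of compound; compound 1 gives 0.1 uM there. For compound 2 the assay reports a limit, > 10 uM, not a number (the limit of > 10 uM in this assay, at which 1 of the 2 values shown sits). The pair differs in more than one place, so nothing beyond these two readings is drawn from it.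

Compound 3 `CNc1nc(N)c2nc(O)n(Cc3ccccc3)c2n1` follows from compound 1 by a single change: methylamino in place of benzylsulfanyl on an aromatic carbon. Among the measured compounds shown here, no measured step of this kind exists in the set. The expectation is a move toward larger amounts, beyond the scatter, given how much of compound 1 departs and how little enters. The estimate for compound 3 is 1 uM, within 0.1 uM to 10 uM, which is expected to amount to a 10-fold higher number from compound 1 to compound 3 (1.00 log units; beyond the scatter).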

Compound 3, minimum effective concentration: 1 uM
Beside the measured number, compound 3's estimate shows no gap at the digits printed; measured number inside the range.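

This position, on an aromatic carbon between two ring nitrogen atoms, gives the series its first readable single-place step: in this assay, methylamino in place of benzylsulfanyl produces a 10-fold higher number from compound 1 to compound 3 (1.00 log units; beyond the scatter) on the core of compound 1. Compound 3 still gives a number, 1 uM in this assay, so the six-membered aromatic ring of benzylsulfanyl is not needed for a measurable effect on this core, though the higher number shows that the exchange is not neutral.

The step swaps the ring, the sulfur and the donor-bearing nitrogen at once, and benzylamino or methylsulfanyl on the same core would be needed to tell these apart. Compound 2 remains a limit, not a number, and differs from compound 1 and compound 3 in more than one place: the limit of > 10 uM in this assay, at which 1 of the 3 values shown sits.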